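A few compounds are considered here, and "the series" means these few. Any claim that something is new, unique, unknown or untested is made for them only; others in the source may bear on it.

Measured in a functional assay on MDA-MB-231 cells (Homo sapiens) for antiproliferative activity, read by sulforhodamine B assay, with a stated time of 72 h; on this read-out higher numbers stand for weaker inhibition and lower numbers for stronger inhibition:
- compound 1 `Cc1ccc(S(=O)(=O)Nc2cc(SCC(=O)N[C@@H](CC(C)C)B(O)O)c(O)c3ccccc23)cc1`: 14000 nM
- compound 2 `CC(C)C[C@H](NC(=O)CSc1cc(NS(=O)(=O)c2ccc(Cl)cc2)c2ccccc2c1O)B(O)O`: 6190 nM
- compound 3 `CC(C)C[C@H](NC(=O)CCSc1cc(NS(=O)(=O)c2ccccc2)c2ccccc2c1O)B(O)O`: 4200 nM

Compound 3 holds the lowest number of the three, but it lies within the scatter of compound 2. Its gap to compound 1 lies beyond the scatter. Compound 4 `CC(=O)Nc1ccc(S(=O)(=O)Nc2cc(SCCC(=O)N[C@@H](CC(C)C)B(O)O)c(O)c3ccccc23)cc1` differs from compound 3 by acetamido in place of hydrogen on an aromatic carbon, para to a large group. Going by the values given here, no measured step introduces acetamido. The nearest guide is the modest step of a 2.3-fold lower number from compound 1 to compound 2 (0.35 log units; beyond the scatter), where chloro replaces methyl on an aromatic carbon. In this assay, the expected move is similarly small or within the scatter, and is estimated as a 1.3-fold higher number from compound 3 to compound 4 (0.12 log units; within the scatter). For compound 4 the estimated value is 5500 nM, with an expected range of 2200 nM to 14000 nM.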

Compound 4, half-maximal inhibitory concentration: 2120 nM
The estimate for compound 4 lay 2.6-fold (0.41 log units) above the measured number; measured number outside the range, below it.
By their numbers in this assay, from the lowest: compounds 4, 3 and 2 (each within the scatter of the next, the first and the last beyond it); then compound 1.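

In this assay, acetamido in place of hydrogen, para to a large group, gives a 2.0-fold lower number from compound 3 to compound 4 (0.30 log units; within the scatter), so phenyl to 4-acetamidophenyl is tolerated without a change beyond the scatter. The earlier compounds shown here carried only hydrogen, methyl or chloro on this ring, and compound 4 extends that range to a larger group with a hydrogen-bond donor and acceptor. No data on hand give a cause for this result. Open, from the compounds shown here alone, is how an amine or a carboxylic acid at this position would read. Also open, going by these compounds, is whether acetamido would give the same result on the shorter chain of compound 2.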